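Amide Substituent Changes in a Lipidated Cysteine TLR2 Agonist Series

A few compounds are considered here, and "the series" means these few. Any claim that something is new, unique, unknown or untested is made for them only; others in the source may bear on it.

Compound 1 `CCCCCCCCCCCC(=O)OC[C@H](CSC[C@@H](N)C(=O)N[C@H](C)CO)OC(=O)CCCCCCCCCCC`: 22200 nM
Compound 2 `CCCCCCCCCCCC(=O)OC[C@H](CSC[C@@H](N)C(=O)NCCCS(=O)(=O)O)OC(=O)CCCCCCCCCCC`: 5560 nM

Among the compounds with values here, in an assay on HEK293 cells for agonist activity at Toll-like receptor 2 (Homo sapiens) (a higher number here means that more compound is needed for the effect, a lower number that less compound is needed), compound 2 gives the lowest of the two numbers; the only other value is that of compound 1, and the step of a 4.0-fold lower number from compound 1 to compound 2 (0.60 log units; beyond the scatter). Compound 3 `CCCCCCCCCCCC(=O)OC[C@H](CSC[C@@H](N)C(=O)NC(C)c1ccccc1)OC(=O)CCCCCCCCCCC` carries 1-phenylethyl in place of 3-sulfopropyl on an amide-type nitrogen. Within the data shown here, no measured step covers this change; the step from compound 1 to compound 2 only shows that the amide substituent moves the number. Compound 3 is therefore expected to shift by a 2.7-fold higher number from compound 2 to compound 3 (0.43 log units; beyond the scatter), towards a higher number. The estimate for compound 3 is 15000 nM, with a range from 3000 nM to 60000 nM.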

Compound 3, half-maximal effective concentration: 9900 nM
Beside the measured number, compound 3's estimate is 1.5-fold (0.18 log units) above it; measured number inside the range.
By their numbers in this assay, from the lowest: compounds 2 and 3 (each within the scatter of the next); then compound 1.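

In this assay, a 1.8-fold higher number from compound 2 to compound 3 (0.25 log units; within the scatter) separates 1-phenylethyl from 3-sulfopropyl on the amide-type nitrogen only within the scatter, so an all-carbon aromatic substituent with no hydrogen-bond donors or acceptors cannot be told apart here from the sulfur-bearing chain. Replacing 1-(hydroxymethyl)ethyl with 1-phenylethyl gives a 2.2-fold lower number from compound 1 to compound 3 (0.35 log units; beyond the scatter) and is thus a second substituent that stands apart from compound 1. No evidence available here bears on these results. Going by these compounds, whether a carboxylic acid, an amine or a longer alkyl chain on this nitrogen would give a similar number remains open.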